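A few compounds are considered here, and "the series" means these few. Any claim that something is new, unique, unknown or untested is made for them only; others in the source may bear on it.

Compound 2 `CCCCCCCCCCC[C@@H](C[C@@H]1OC(=O)[C@H]1CCCCCC)OC(=O)[C@@H](NC(C)=O)C(C)C` holds the only numerical result in an assay on COS-7 cells for inhibition of diacylglycerol lipase-alpha (Homo sapiens), read by scintillation counting (on this read-out lower numbers stand for stronger inhibition and higher numbers for weaker inhibition), where compound 2 gives 460 nM. Compound 1 `CCCCCCCCCCC[C@@H](C[C@@H]1OC(=O)[C@H]1CCCCCC)OC(=O)[C@@H](N)CC(C)C` is reported in this assay only as a limit, > 25000 nM. For the measured compounds named here, the single measured step, an at least 54-fold lower number from compound 1 to compound 2 (1.73 log units; beyond the scatter), runs from that limit of > 25000 nM in this assay, at which 1 of the 2 values shown sits, and concerns a different change. Compound 3 `CCCCCCCCCCC[C@@H](C[C@@H]1OC(=O)[C@H]1CCCCCC)OC(=O)[C@@H]1CCC(=O)N1` differs from compound 2 by 5-oxopyrrolidin-2-yl in place of 1-acetamido-2-methylpropyl on a carbonyl carbon. Going by the values given here, no measured step covers this change, so the expectation rests on compound 2 alone, with a modest weakening expected as a 3.3-fold higher number from compound 2 to compound 3 (0.51 log units; beyond the scatter). Compound 3 is therefore estimated at 1500 nM, with a range from 300 nM to 8000 nM.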

Compound 3, half-maximal inhibitory concentration: 100 nM
Beside the measured number, compound 3's estimate is 15-fold (1.18 log units) above it; measured number outside the range, below it.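

Replacing the open-chain 1-acetamido-2-methylpropyl group on the carbonyl carbon with the 5-oxopyrrolidin-2-yl ring improves inhibition in this assay, giving a 4.6-fold lower number from compound 2 to compound 3 (0.66 log units; beyond the scatter). The counts of hydrogen-bond donors and acceptors stay the same, so this position accepts a ring and rewards it here. The wider step, an at least 250-fold lower number from compound 1 to compound 3 (2.39 log units; beyond the scatter), gives only a minimum size, and compound 1 stands at a limit: the limit of > 25000 nM in this assay, at which 1 of the 3 values shown sits.

The two groups differ both in the ring and in the branched chain, and these compounds do not separate the two. On these data alone, how a six-membered lactam or a methyl group on the ring nitrogen would fare remains open.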